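This account rests on a few compounds, and the source may have more. Where it says the series, first, only, none or still open, it means among the compounds named here.

For the measured compounds named here, compound 2 `Brc1ccc(OC[C@H]2CCN2)cn1` holds the lowest of the two numbers measured so far. In an assay on brain for binding affinity to Neuronal acetylcholine receptor; alpha4/beta2 (Rattus norvegicus), read by radioligand binding (a lower number here means a stronger inhibitor, a higher number a weaker inhibitor), compound 2 gives 0.17 nM, while compound 1 `COc1ccc(OC[C@@H]2CCN2)cn1` gives 1.3 nM in this assay, a gap that lies beyond the scatter of repeated measurements. Compound 3 `COc1ccc(OC[C@H]2CCN2)cn1` has not yet been measured in this assay. It differs from compound 2 in one place: methoxy in place of bromo on an aromatic carbon. Going by the values given here, no measured pair shows exactly this exchange, so the size of its effect is unknown. Some loss of affinity in this assay is expected, because compound 1, which also bears a methoxy group, gives 1.3 nM, a weaker result than compound 2. The step is expected to be modest, perhaps slightly beyond the scatter, with a 5.9-fold higher number from compound 2 to compound 3 (0.77 log units; beyond the scatter) as the estimated change. For compound 3 the expected value in this assay is 1 nM, within a range from 0.3 nM to 4 nM.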

Compound 3, inhibition constant: 0.67 nM
The estimate for compound 3 lay 1.5-fold (0.17 log units) above the measured number; the range from low to high includes it.
By their numbers in this assay, from the lowest: compound 2; then compounds 3 and 1 (each within the scatter of the next).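

In this assay, the exchange on this aromatic carbon, next to the ring nitrogen, gives a 3.9-fold higher number from compound 2 to compound 3 (0.60 log units; beyond the scatter), so methoxy in place of bromo carries a modest cost that can now be read on its own. The change of drawn configuration at the saturated ring carbon gives a 1.9-fold lower number from compound 1 to compound 3 (0.29 log units; within the scatter), so with methoxy on the ring this stereocentre does not separate the two compounds beyond the scatter. That reading of the stereocentre rests on one fact: the fact that compounds 1 and 3 differ only in the configuration as drawn.

The compounds shown hold only bromo and methoxy on this carbon, and how chloro, an amine or the longer ethoxy would behave there stays open. As far as these compounds go, the two configurations are compared only with methoxy on the ring, and whether they also stay this close with bromo there is unknown.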